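Pentyl Ether in Place of a Free Hydroxy: Expected Potency

The source may hold more compounds than are shown below. What is called first, only, known or untested is meant among the compounds shown, and "the series" means these compounds.

Compound 1 `C=CCOc1ccccc1C1CC(=O)c2ccccc2O1`: 38600 nM
Compound 2 `O=C1CC(c2ccccc2O)Oc2ccccc21`: 71300 nM
Compound 3 `COc1ccccc1C1CC(=O)c2ccccc2O1`: 44500 nM

Three compounds share one core and differ only in what sits on an oxygen on an aromatic ring. In a functional assay on J774.A1 cells (Mus musculus) for inhibition, read by Griess assay, with stated times of 1 h and 24 h (a lower number here means a stronger inhibitor, a higher number a weaker inhibitor), compound 2 gives the highest of the three numbers, yet its gaps to compound 3 and to compound 1 are both within the scatter, so the three cannot be ranked against each other. Compound 4 `CCCCCOc1ccccc1C1CC(=O)c2ccccc2O1` has not been measured; it differs from compound 2 as follows: pentyl in place of hydrogen on an oxygen on an aromatic ring. For the measured compounds named here, two measured steps bear on this change, a 1.6-fold lower number from compound 2 to compound 3 (0.20 log units; within the scatter) and a 1.8-fold higher number from compound 1 to compound 2 (0.27 log units; within the scatter), and both are small. Going by the values given here, replacing the hydrogen with a methyl or an allyl changed little, and a pentyl is a longer chain for which no measured compound gives direct guidance. For compound 4 a step of a 1.8-fold lower number from compound 2 to compound 4 (0.25 log units; within the scatter) is therefore expected, at most modest. Compound 4 is estimated at 40000 nM, with a range from 15000 nM to 110000 nM.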

Compound 4, half-maximal inhibitory concentration: 39300 nM
Compound 4: the middle estimate sits 1.0-fold (0.01 log units) above what was measured; low and high end bracket the measured number.
By their numbers in this assay, from the lowest: compounds 1, 4, 3 and 2 (each within the scatter of the next).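

In this assay the change from hydroxy to pentyloxy gives a 1.8-fold lower number from compound 2 to compound 4 (0.26 log units; within the scatter) and so extends the flat picture on this oxygen to a chain of five carbons, where the methyl and allyl groups had shown it only for shorter ones. Against those shorter ethers the pentyl chain gives a 1.1-fold lower number from compound 3 to compound 4 (0.05 log units; within the scatter) and a 1.0-fold higher number from compound 1 to compound 4 (0.01 log units; within the scatter) as well, so among compound 1, compound 2, compound 3 and compound 4 no step at this position can be told apart from the scatter of repeated measurements. No measurement is at hand that would explain this flatness.

A decyl chain, or a shorter chain ending in an amine or a carboxylic acid, lies outside the compounds shown. From the compounds shown here alone, whether any group on this oxygen can move the number beyond the scatter therefore stays open.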